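Sulfonyl aryl replacement in a chemokine receptor binder series

A few compounds are considered here, and "the series" means these few. Any claim that something is new, unique, unknown or untested is made for them only; others in the source may bear on it.

Measured compounds:
compound 1: `O=C(NCc1ccc(CNS(=O)(=O)c2ccccc2Cl)cc1)c1cccnc1` — 100 nM
compound 2: `Cc1ccccc1C(=O)NCc1ccc(CNS(=O)(=O)c2ccc(Cl)cc2)cc1` — 1 nM
compound 3: `COc1ccccc1C(=O)NCc1ccc(CNS(=O)(=O)c2ccccc2F)cc1` — 1 nM

In an assay on MDA-MB-231 cells for displacement of a labelled ligand from C-X-C chemokine receptor type 4 (Homo sapiens), read by fluorescence and microscopy, with stated times of 10 min and 30 min (on this read-out higher numbers stand for an effect only at larger amounts of compound and lower numbers for an effect already at smaller amounts), compound 1 gives 100 nM, the highest of the three numbers. Compound 2 gives 1 nM and compound 3 gives 1 nM; each of these sits far below compound 1, beyond the scatter, while compound 2 and compound 3 cannot be told apart from each other. Within the data shown here, both of them differ from compound 1 in more than one place at once, so no measured pair isolates a single change and no step can be drawn from them.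

Compound 4, `O=C(NCc1ccc(CNS(=O)(=O)c2cccc3ccccc23)cc1)c1cccnc1`, differs from compound 1 in one place: naphthalen-1-yl in place of 2-chlorophenyl on a sulfonyl sulfur. Among the measured compounds shown here, no measured pair shows this change, and the three numbers give no guide to its direction. The step is therefore expected to be small, most likely toward a lower number but possibly not beyond the scatter. Compound 4 is expected to give 50 nM in this assay, within 10 nM to 300 nM. The step of a 2.0-fold lower number from compound 1 to compound 4 (0.30 log units; within the scatter) is the expected size of that move.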

Compound 4, effective concentration (reported as EC, without a stated level of effect): 1000 nM
Compound 4: middle estimate off by 20-fold (1.30 log units), on the low side; the whole stated range lies below it.
By their numbers in this assay, from the lowest: compounds 2 and 3 (each within the scatter of the next); then compound 1; then compound 4.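

In this assay, the aryl group on the sulfonyl sulfur now has its first single-place reading, with naphthalen-1-yl in place of 2-chlorophenyl giving a 10-fold higher number from compound 1 to compound 4 (1.00 log units; beyond the scatter). The number at this position therefore depends on which aryl group is present, and here the second six-membered aromatic ring and the loss of chlorine arrive together with the higher number. Nothing available explains this move.

Going by these compounds, whether the higher number follows the added ring or the missing chlorine remains open, as does whether the same replacement would read alike in compound 2 and compound 3, which carry different groups elsewhere. Also open, on these data alone, is how an unsubstituted phenyl, or a phenyl bearing a dimethylamino group or a carboxylic acid, would read on this sulfonyl sulfur.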